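The source may report more compounds than this note shows. Statements on the series, on what has been measured and on what is new or still open speak of the compounds shown alone.

In a functional assay on HL-60 cells (Homo sapiens) for cytotoxicity, read by WST assay, with a stated time of 48 h (on this read-out lower numbers stand for stronger inhibition and higher numbers for weaker inhibition), compound 2 `O[C@@H](c1ccccc1)[C@H]1CO[C@H](c2ccccc2)[C@@H](C/C=C/c2ccccn2)C1` gives 36400 nM. Its closest neighbour is compound 1 `COc1ccc(/C=C/C[C@H]2C[C@H]([C@H](O)c3ccc(OC)c(OC)c3)CO[C@@H]2c2ccc(OC)c(OC)c2)cc1OC`, which in this assay gives 23500 nM; the gap between the two is inside the scatter of repeated measurements, so no difference between them can be claimed. For compound 3 `COc1ccc(/C=C/C[C@@H]2C[C@H]([C@H](O)c3ccc(OC)c(OC)c3)CO[C@H]2c2ccc(OC)c(OC)c2)cc1OC` the result in this assay is "not determined" (no result reported); it differs from compound 1 only in the configuration as drawn (the fact that compounds 1 and 3 differ only in the configuration as drawn). Compound 4 `COc1ccccc1/C=C/C[C@H]1C[C@@H]([C@@H](O)c2ccccc2)CO[C@@H]1c1ccccc1` differs from compound 2 by one change: 2-methoxyphenyl in place of pyridin-2-yl on a double-bonded chain carbon bound to a double-bonded chain carbon. Among the measured compounds shown here, with no measured pair sharing this change, the step is expected to stay within the scatter, perhaps leaning toward a lower number. The estimated value for compound 4 in this assay is 26000 nM, within 8000 nM to 80000 nM, which would mean a step of a 1.4-fold lower number from compound 2 to compound 4 (0.15 log units; within the scatter).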

Compound 4, half-maximal inhibitory concentration: 10100 nM
Beside the measured number, compound 4's estimate is 2.6-fold (0.41 log units) above it; measured number inside the range.
By their numbers in this assay, from the lowest: compound 4; then compounds 1 and 2 (each within the scatter of the next).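

Among the compounds shown here, this place on the chain is not neutral: with 2-methoxyphenyl in place of pyridin-2-yl, this assay shows a 3.6-fold lower number from compound 2 to compound 4 (0.56 log units; beyond the scatter) and this is the first single-place step here that can be read. No fact given here accounts for this step. As far as these compounds go, it remains open whether the step comes from the added methoxy group or from the loss of the ring nitrogen, and how a ring carrying an amine or a carboxylic acid would behave at this place.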